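This account rests on a few compounds, and the source may have more. Where it says the series, first, only, none or still open, it means among the compounds named here.

Measured compounds in an assay on microsomes from liver for inhibition of 3-hydroxy-3-methylglutaryl-coenzyme A reductase (Rattus norvegicus); a lower number here means a stronger inhibitor, a higher number a weaker inhibitor:
compound 1 `CC(C)c1c(C(=O)N(C)Cc2ccccc2)nn(-c2ccc(F)cc2)c1OC[C@@H](O)C[C@@H](O)CC(=O)O`: 5.2 nM
compound 2 `COCc1cccc(CNC(=O)c2nn(-c3ccc(F)cc3)c(OC[C@@H](O)C[C@@H](O)CC(=O)O)c2C(C)C)c1`: 31 nM
compound 3 `Cc1cccc(CN(C)C(=O)c2nn(-c3ccc(F)cc3)c(OC[C@@H](O)C[C@@H](O)CC(=O)O)c2C(C)C)c1`: 37 nM

Compound 3 gives the highest of the three numbers in this assay; compound 2 lies within the scatter of it, while compound 1 stands well apart, as the step of a 7.1-fold higher number from compound 1 to compound 3 (0.85 log units; beyond the scatter) shows. Compound 4 `CC(C)c1c(C(=O)N(C)Cc2ccc(F)cc2)nn(-c2ccc(F)cc2)c1OC[C@@H](O)C[C@@H](O)CC(=O)O` differs from compound 3 by 4-fluorophenyl in place of 3-methylphenyl on a saturated chain carbon bound to an amide-type nitrogen. For the measured compounds named here, because the step of a 7.1-fold higher number from compound 1 to compound 3 (0.85 log units; beyond the scatter) introduced the methyl that now leaves, it bears on this change directly; the fluorine that enters has no measured counterpart. The steps of a 6.0-fold higher number from compound 1 to compound 2 (0.78 log units; beyond the scatter) and a 1.2-fold higher number from compound 2 to compound 3 (0.08 log units; within the scatter) concern other groups and add little. Compound 4 is therefore expected to fall between compound 1 and compound 3, with the step of a 3.7-fold lower number from compound 3 to compound 4 (0.57 log units; beyond the scatter) expected in this assay. The estimate for compound 4 is 10 nM, range 4 nM to 25 nM.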

Compound 4, half-maximal inhibitory concentration: 18 nM
Compound 4: middle estimate off by 1.8-fold (0.26 log units), on the low side, and the stated range covers the measured number.
By their numbers in this assay, from the lowest: compound 1; then compounds 4, 2 and 3 (each within the scatter of the next, the first and the last beyond it).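

In this assay, the added fluorine also raises the number, a 3.5-fold higher number from compound 1 to compound 4 (0.54 log units; beyond the scatter), so both substituted benzyl amides with the methyl on nitrogen, compound 3 and compound 4, lie above the unsubstituted benzyl of compound 1. The substituent still matters, since 4-fluorophenyl in place of 3-methylphenyl gives a 2.1-fold lower number from compound 3 to compound 4 (0.31 log units; beyond the scatter), whereas a 1.7-fold lower number from compound 2 to compound 4 (0.24 log units; within the scatter) stays within the scatter. Nothing measured here explains these steps.

Element and ring location change together here, so the effect of each remains unseparated. 3-fluorobenzyl and 4-methylbenzyl would separate them, and 4-chlorobenzyl would test another halogen.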